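Replacing 4-methoxyphenyl with 3-nitrophenyl in compound 2

The source may hold more compounds than are shown below. What is called first, only, known or untested is meant among the compounds shown, and "the series" means these compounds.

In a functional assay on OVCAR-3 cells (Homo sapiens) for cytotoxicity, read by sulforhodamine B assay (a lower number here means that less compound is tolerated, a higher number that more compound is tolerated), compound 1 (`CC1=CC[C@@H]([C@@](C)(O)CCCC(C)(C)NC=S)CC1`) reports only a limit, > 100000 nM, and not a number. Going by the values given here, compound 2 (`COc1ccc(/C=N\NC(=S)NC(C)(C)CCC[C@](C)(O)[C@@H]2CC=C(C)CC2)cc1`) gives the only true number so far, 46200 nM. Compound 3 (`CC1=CC[C@@H]([C@@](C)(O)CCCC(C)(C)NC(=S)N/N=C\c2cccc([N+](=O)[O-])c2)CC1`) differs from compound 2 as follows: 3-nitrophenyl in place of 4-methoxyphenyl on a carbon with a double bond to nitrogen. Put simply, 3-nitrophenyl sits in place of 4-methoxyphenyl on a carbon with a double bond to nitrogen. Among the compounds with values here, no measured pair shows what such a swap does, so only a modest move toward a lower number is expected, an estimated 1.4-fold lower number from compound 2 to compound 3 (0.16 log units; within the scatter). For compound 3 the expected value is 32000 nM, with an estimated range from 11000 nM to 90000 nM.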

Compound 3, concentration lethal to 50% of the cells: > 100000 nM
Compound 3 gave a limit, no number (the forecaster's own chance of this, stated with the estimate: 15%); at least 3.1-fold (0.49 log units) between middle value and limit.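

In this assay, the group on this carbon with a double bond to nitrogen does change the read-out: 3-nitrophenyl in place of 4-methoxyphenyl gives an at least 2.1-fold higher number from compound 2 to compound 3 (0.33 log units; beyond the scatter), so more compound is tolerated. Compound 3 gives only a limit and not a number, so the full size of this step cannot be read, because the assay stops at a ceiling: the limit of > 100000 nM in this assay, at which 2 of the 3 values shown sit.

The compounds shown leave open whether the nitro group itself or its place on the ring drives this step. On these data alone, how a 4-aminophenyl or 3-carboxyphenyl group would read at this position also remains open.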